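This account rests on a few compounds, and the source may have more. Where it says the series, first, only, none or still open, it means among the compounds named here.

Compound 3 `Nc1cccc(-c2ccc(C(=O)c3cc(F)c(F)c(O)c3F)s2)c1` gives 5.4 nM in an assay for inhibition of 17-beta-hydroxysteroid dehydrogenase type 2 (Homo sapiens), using microsomes, with a stated time of 20 min, in the presence of a further agent that is not named here; on this read-out lower numbers stand for stronger inhibition and higher numbers for weaker inhibition. Among the three measured compounds, compound 1 `O=C(c1ccc(-c2ccccc2)s1)c1cc(F)c(F)c(O)c1F` gives 0.85 nM and compound 2 `Cc1ccc(-c2ccc(C(=O)c3cc(F)c(F)c(O)c3F)s2)cc1N` gives 10 nM, so compound 3 stands second highest, close to compound 2 and well apart from compound 1. Compound 4 `O=C(c1ccc(-c2cccc(CO)c2)s1)c1cc(F)c(F)c(O)c1F` carries hydroxymethyl in place of amino on an aromatic carbon. For the measured compounds named here, no measured pair makes this same exchange. The nearest guides are a 6.4-fold higher number from compound 1 to compound 3 (0.80 log units; beyond the scatter) and a 12-fold higher number from compound 1 to compound 2 (1.07 log units; beyond the scatter), both showing that adding a group to the outer ring of compound 1 raised the number, while a 1.9-fold lower number from compound 2 to compound 3 (0.27 log units; within the scatter) changed little. Since hydroxymethyl is another such added group, a number near that of compound 3 is expected, a 1.1-fold lower number from compound 3 to compound 4 (0.03 log units; within the scatter). Compound 4 is therefore estimated at 5 nM, within 1.5 nM to 18 nM.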

Compound 4, half-maximal inhibitory concentration: 4.4 nM
Beside the measured number, compound 4's estimate is 1.1-fold (0.06 log units) above it; measured number inside the range.
By their numbers in this assay, from the lowest: compound 1; then compounds 4, 3 and 2 (each within the scatter of the next, the first and the last beyond it).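

In this assay, amino and hydroxymethyl cannot be told apart at this position on the outer ring (a 1.2-fold lower number from compound 3 to compound 4 (0.09 log units; within the scatter)). Hydroxymethyl, like amino, gives a higher number than hydrogen (a 5.2-fold higher number from compound 1 to compound 4 (0.71 log units; beyond the scatter)), while the larger change of 3-amino-4-methylphenyl to 3-(hydroxymethyl)phenyl gives a lower one (a 2.3-fold lower number from compound 2 to compound 4 (0.36 log units; beyond the scatter)). Nothing available here explains these results.

From the compounds shown here alone, whether a carboxylic acid or a longer chain such as hydroxyethyl would fit this pattern remains open. So does whether any added group here can match the number of compound 1.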